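The source may hold more compounds than are shown below. What is called first, only, known or untested is meant among the compounds shown, and "the series" means these compounds.

Working notes on the series. Compound 1 `COc1ccc(-c2cc(/C=C/C(=O)c3ccc(N)cc3)[nH]n2)cc1` and compound 2 `COc1cc(-c2cc(/C=C/C(=O)c3ccc(N)cc3)[nH]n2)cc(OC)c1OC` share one core and differ only in the methoxy pattern of the aryl ring. In a functional assay on SK-OV-3 cells (Homo sapiens) for cytotoxicity, read by sulforhodamine B assay, with a stated time of 48 h, tested at 100 uM (on this read-out higher numbers stand for a weaker effect at the one concentration tested and lower numbers for a stronger effect), compound 1 gives -68%, while compound 2 gives -98%, the lowest of the two numbers; the gap to compound 1 lies beyond the scatter. Compound 3 `COc1ccc(-c2cc(/C=C/C(=O)c3ccc(N)cc3)[nH]n2)cc1OC` has not yet been measured. Its structure differs from compound 2 by hydrogen in place of methoxy on an aromatic carbon. Within the data shown here, no step between measured compounds is available for this change; the two values at hand show only that compound 2 sits lower than compound 1. On that basis compound 3 is expected to land between the two measured values. The step of a number 13 percentage points higher from compound 2 to compound 3 (beyond the scatter) is estimated to run upward, roughly at the edge of the scatter. For compound 3 the estimate in this assay is -85%, with a range from -100% to -65%.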

Compound 3, a percentage reported as activity, at one concentration (the size of the read-out at that concentration, not a potency): -99%
Estimate against measurement, compound 3: 14 percentage points above, and the stated range covers the measured number.
By their numbers in this assay, from the lowest: compounds 3 and 2 (each within the scatter of the next); then compound 1.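

In this assay hydrogen in place of methoxy on an aromatic carbon, ortho to a methoxy group and meta to a large group, gives a number 1 percentage points lower from compound 2 to compound 3 (within the scatter), so this methoxy can go without a readable change in the read-out. Methoxy in place of hydrogen on an aromatic carbon gives a number 31 percentage points lower from compound 1 to compound 3 (beyond the scatter) and is a large step. The gap between compound 1 and compound 2 is therefore already present at compound 3, and the further methoxy of compound 2 adds nothing readable. No measurement at hand gives a reason for either step.

From the compounds shown here alone, it remains open how a hydroxyl, an amine or a longer alkoxy chain would behave at the position ortho to a methoxy group. The compounds shown also do not tell whether a single methoxy at another place on the aryl ring would carry the large step.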